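Replacing the 4-methoxybenzyl group of compound 3

The compounds below may be only part of what the source reports. "The series", "measured", "known", "first", "only" and "open" are said of these compounds alone.

Of the compounds shown here, three have so far been measured in a functional assay on HCC827 cells (Homo sapiens) for inhibition, read by fluorescence, with a stated time of 72 h; on this read-out higher numbers stand for weaker inhibition of growth and lower numbers for stronger inhibition of growth. Compound 1 (`CC(C)CCn1cnc2c(Nc3ccc(Cl)cc3)nc(N[C@H]3CC[C@H](N)CC3)nc21`) reads 10200 nM in it, compound 2 (`N[C@H]1CC[C@H](Nc2nc(Nc3ccc(Cl)cc3)c3ncn(C4CCCCC4)c3n2)CC1`) reads 9100 nM in it, and compound 3 (`COc1ccc(Cn2cnc3c(Nc4cccc(Cl)c4)nc(N[C@H]4CC[C@H](N)CC4)nc32)cc1`) reads 18700 nM there. Compound 3 thus lies within the scatter of compound 1 and beyond the scatter only against compound 2, whose number is lower.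

Compound 4 (`CC(C)=CCn1cnc2c(Nc3cccc(Cl)c3)nc(N[C@H]3CC[C@H](N)CC3)nc21`) differs from compound 3 in one place: 2-methylprop-1-en-1-yl in place of 4-methoxyphenyl on a saturated chain carbon bound to an aromatic nitrogen. Cut one bond further out, the change reads 4-methoxybenzyl to 3-methylbut-2-en-1-yl.

Among the compounds with values here, no measured step covers this exchange directly, and compounds 1 and 2 also differ from compound 3 elsewhere. The nearest evidence is a 1.1-fold lower number from compound 1 to compound 2 (0.05 log units; within the scatter) for cyclohexyl in place of isopentyl on an aromatic nitrogen. That single small step is thin support, but it gives no reason to expect a large move here, so at most a slight drift towards the numbers of compounds 1 and 2 is expected in this assay. The estimate amounts to a 1.6-fold lower number from compound 3 to compound 4 (0.19 log units; within the scatter) and so to no expected change beyond the scatter. Compound 4 is estimated at 12000 nM with an expected range from 6000 nM to 24000 nM in this read-out.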

Compound 4, concentration for 50% growth inhibition: 13500 nM
The estimate for compound 4 lay 1.1-fold (0.05 log units) below the measured number, within the range that was stated.
By their numbers in this assay, from the lowest: compounds 2, 1, 4 and 3 (each within the scatter of the next, the first and the last beyond it).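

Exchanging 4-methoxybenzyl for 3-methylbut-2-en-1-yl gives a 1.4-fold lower number from compound 3 to compound 4 (0.14 log units; within the scatter) in this assay and so stays within the scatter. At this place, on a saturated chain carbon bound to an aromatic nitrogen, the six-membered aromatic ring and its methoxy oxygen can therefore give way to a smaller open group with one double bond, with no change beyond the scatter in growth inhibition; the earlier step between isopentyl and cyclohexyl, a 1.1-fold lower number from compound 1 to compound 2 (0.05 log units; within the scatter), compared only groups without a double bond or an aromatic ring and had not shown this. No data at hand give a reason for how little the number moves here.

Since the aromatic ring and the methoxy group leave together in this one step, the compounds shown cannot separate what each contributes, and a plain benzyl group would be needed to tell them apart. Also open, from the compounds shown here alone, is whether a group of another kind at this place, such as a carboxylic acid or a hydroxyl group in place of the 3-methylbut-2-en-1-yl group, would shift the number beyond the scatter.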